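The source may hold more compounds than are shown below. What is called first, only, known or untested is meant among the compounds shown, and "the series" means these compounds.

Four compounds built on one shared core are considered here, and all of them belong in a functional assay on MCF7 cells (Homo sapiens) for cytotoxicity, read by MTT assay, with a stated time of 48 h; a lower number here means a stronger inhibitor, a higher number a weaker inhibitor. Compound 1 `CNC(=O)CSc1nc2ccc(NC(=O)c3ccccc3)cc2s1` gives 34400 nM in this assay. Compound 2 `O=C(CSc1nc2ccc(NC(=O)c3ccccc3)cc2s1)NCc1ccccc1` differs from compound 1 by phenyl in place of hydrogen on a saturated chain carbon bound to an amide-type nitrogen, and in this assay compound 2 gives 35600 nM, so that a 1.0-fold higher number from compound 1 to compound 2 (0.01 log units; within the scatter). Compound 3 `CNC(=O)CSc1nc2ccc(NC(=O)c3ccc(Cl)cc3)cc2s1` differs from compound 1 by chloro in place of hydrogen on an aromatic carbon; in this assay compound 3 gives 29400 nM, and a 1.2-fold lower number from compound 1 to compound 3 (0.07 log units; within the scatter). Compound 2 and compound 3 are not joined by a single-point step, and their two values simply sit close to one another.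

Compound 4 `O=C(CSc1nc2ccc(NC(=O)c3ccc(Cl)cc3)cc2s1)NCc1ccccc1` has not yet been measured in this assay. It differs from compound 3 by phenyl in place of hydrogen on a saturated chain carbon bound to an amide-type nitrogen. This is the same change that separates compound 2 from compound 1, with the place described in the same words, and the two cores on which it is made differ by chloro in place of hydrogen on an aromatic carbon. When the change was made from compound 1 to compound 2 it produced a 1.0-fold higher number from compound 1 to compound 2 (0.01 log units; within the scatter).

Compound 4 is therefore expected to give about 30000 nM in this assay, with the likely range running from 17000 nM to 55000 nM, because the earlier instance of this change gave a 1.0-fold higher number from compound 1 to compound 2 (0.01 log units; within the scatter) and compound 3 starts from 29400 nM. The estimated step that this implies is a 1.0-fold higher number from compound 3 to compound 4 (0.01 log units; within the scatter), which is expected to stay within the usual scatter.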

Compound 4, half-maximal inhibitory concentration: 25900 nM
Estimate against measurement, compound 4: 1.2-fold (0.06 log units) above; the range from low to high includes it.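

In this assay, phenyl in place of hydrogen on a saturated chain carbon bound to an amide-type nitrogen gives a 1.1-fold lower number from compound 3 to compound 4 (0.06 log units; within the scatter), and this agrees with the same change made on the core of compound 1: the same change on two cores in this assay, a 1.0-fold higher number (0.01 log units; within the scatter) from compound 1 to compound 2 and a 1.1-fold lower number (0.06 log units; within the scatter) from compound 3 to compound 4, 1.2-fold (0.07 log units) apart, within the scatter of two such steps The chloro change reads the same way, with a 1.4-fold lower number from compound 2 to compound 4 (0.14 log units; within the scatter), and it also agrees with its earlier instance: the same change on two cores in this assay, a 1.2-fold lower number (0.07 log units; within the scatter) from compound 1 to compound 3 and a 1.4-fold lower number (0.14 log units; within the scatter) from compound 2 to compound 4, 1.2-fold (0.07 log units) apart, within the scatter of two such steps Both changes therefore carry across the two cores shown without a detectable difference, but since every step among these four compounds lies within the scatter, this shows only that neither change moved the number measurably on either core, not that a real effect of either group transfers from one core to another.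

As far as these compounds go, whether a change can produce a step beyond the scatter remains open, for example an amine, a carboxylic acid or a longer chain in place of the benzyl, or methoxy or a nitrile in place of the chloro. The compounds shown also leave open whether the agreement between cores would hold for a change with a larger step, or in any other cell line.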